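Allyl for Propyl on a Carbamate Selenocyanate

A few compounds are considered here, and "the series" means these few. Any claim that something is new, unique, unknown or untested is made for them only; others in the source may bear on it.

Compound 1 `CC(C)COC(=O)Nc1ccc([Se][Se]c2ccc(NC(=O)OCC(C)C)cc2)cc1` gives 42700 nM in an ADME assay on BEAS-2B cells (Homo sapiens) for cytotoxicity, read by MTT assay, with a stated time of 72 h; a lower number here means a stronger inhibitor of growth, a higher number a weaker inhibitor of growth.
Compound 2 `CCCOC(=O)Nc1ccc([Se]C#N)cc1` gives 46300 nM in this assay.
Compound 3 `CCCCCCOC(=O)Nc1ccc([Se][Se]c2ccc(NC(=O)OCCCCCC)cc2)cc1` gives 6900 nM in this assay.

Compound 2 stands at the top of these three numbers, yet compound 1 lies within the usual scatter of it, so the two cannot be told apart on this evidence. Only compound 3 sits beyond the scatter, with the lower number, and it is the single diselenide here that does so; compound 1, also a diselenide, does not.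

Compound 4 `C=CCOC(=O)Nc1ccc([Se]C#N)cc1` differs from compound 2 in one place: vinyl in place of ethyl on a saturated chain carbon bound to an oxygen next to a carbonyl group. Going by the values given here, no pair of measured compounds differs by this change alone, so there is no measured step to lean on, and the expectation rests on the size of the change and on compound 2 alone. The expected step is a 1.2-fold lower number from compound 2 to compound 4 (0.06 log units; within the scatter) in this assay, one that is not expected to reach beyond the scatter in either direction. For compound 4 the estimate in this assay is 40000 nM, expected to fall between 15000 nM and 110000 nM.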

Compound 4, concentration for total growth inhibition: 47400 nM
Compound 4: middle estimate off by 1.2-fold (0.07 log units), on the low side; low and high end bracket the measured number.
By their numbers in this assay, from the lowest: compound 3; then compounds 1, 2 and 4 (each within the scatter of the next).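

In this assay the exchange of propyl for allyl on the selenocyanate gives a 1.0-fold higher number from compound 2 to compound 4 (0.01 log units; within the scatter) and so leaves the two compounds indistinguishable. Going by these compounds alone, this is the first measured step at this position, a saturated chain carbon bound to an oxygen next to a carbonyl group, and it shows that vinyl can stand in place of ethyl there without a change that rises above the scatter, even though the exchange brings in a double bond outside aromatic rings. Nothing available explains this flat result, which therefore stands as an observation only.

From the compounds shown here alone, whether a longer chain such as hexyl, or an amine or a carboxylic acid carried on the chain, would leave the number of the selenocyanate just as undisturbed remains open. Within the data shown here, also open is whether propyl to allyl would prove as small a step on a diselenide of the kind seen in compound 1 and compound 3, since the one step in hand comes from the selenocyanate alone.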